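The compounds below may be only part of what the source reports. "The series", "measured", "known", "first", "only" and "open" are said of these compounds alone.

Working notes on the series. Compound 1 `COc1cc(/C=C/c2nc(NC3CC3)c3sccc3n2)cc(OC)c1OC` gives 6030 nM in a functional assay on RAW264.7 cells (Mus musculus) for inhibition, read by Griess assay, with stated times of 1 h and 24 h; on this read-out lower numbers stand for stronger inhibition and higher numbers for weaker inhibition. Compound 2 `COc1cc(/C=C/c2nc(Nc3ccc(C(F)(F)F)cc3)c3sccc3n2)cc(OC)c1OC` gives 9360 nM in this assay, and compound 3 `COc1cc(/C=C/c2nc(Nc3ccc(O)cc3)c3sccc3n2)cc(OC)c1OC` gives 4070 nM, the lowest of the three numbers, within the scatter of compound 1 and beyond it only against compound 2. Compound 4 `COc1cc(/C=C/c2nc(NCc3ccccc3)c3sccc3n2)cc(OC)c1OC` is not yet measured; it differs from compound 3 by benzyl in place of 4-hydroxyphenyl on a nitrogen on an aromatic ring. Bearing on this are the steps of a 1.5-fold lower number from compound 1 to compound 3 (0.17 log units; within the scatter) and a 1.6-fold higher number from compound 1 to compound 2 (0.19 log units; within the scatter), both within the scatter, and a 2.3-fold lower number from compound 2 to compound 3 (0.36 log units; beyond the scatter). Exchanges on this nitrogen have so far shifted the number little, while removal of the hydroxy is expected to cost a modest amount, so compound 4 is expected to show a 1.5-fold higher number from compound 3 to compound 4 (0.17 log units; within the scatter). The estimate for compound 4 is 6000 nM, with a range of 2500 nM to 14000 nM.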

Compound 4, half-maximal inhibitory concentration: 8260 nM
Estimate against measurement, compound 4: 1.4-fold (0.14 log units) below; low and high end bracket the measured number.
By their numbers in this assay, from the lowest: compounds 3, 1, 4 and 2 (each within the scatter of the next, the first and the last beyond it).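

In this assay, the step of a 2.0-fold higher number from compound 3 to compound 4 (0.31 log units; beyond the scatter) is the second at this nitrogen to lie beyond the scatter, and like the first it involves 4-hydroxyphenyl, though compound 1 goes against any clean separation, as it stands within the scatter of compound 3. Benzyl does not separate from the other two groups: a 1.4-fold higher number from compound 1 to compound 4 (0.14 log units; within the scatter) and a 1.1-fold lower number from compound 2 to compound 4 (0.05 log units; within the scatter) both lie within the scatter. Nothing available accounts for these steps. Still open, from the compounds shown here alone, is how a 4-hydroxybenzyl group on this nitrogen would read, and whether a 4-aminophenyl or 4-methoxyphenyl group would track 4-hydroxyphenyl.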